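A few compounds are considered here, and "the series" means these few. Any claim that something is new, unique, unknown or untested is made for them only; others in the source may bear on it.

Working notes on the series. Compound 1 `CC(C)OC(=O)N1CCC(Oc2ncnc3c2CCN3c2ccc(S(C)(=O)=O)cc2F)CC1` carries an isopropoxycarbonyl group on the piperidine and a methylsulfonyl group on the aromatic ring. Among the measured compounds shown here, in a functional assay on CHO-K1 cells for agonist activity at Glucose-dependent insulinotropic receptor (Homo sapiens), read by a luciferase reporter, with a stated time of 5 h (a lower number here means that less compound is needed, a higher number that more compound is needed for the effect), compound 1 gives 50.1 nM, the lowest of the two numbers measured so far. Compound 2 `CC(C)OC(=O)N1CCC(Oc2ncnc3c2CCN3c2ccc(-c3nccs3)cc2F)CC1` keeps the same core and replaces the methylsulfonyl with 1,3-thiazol-2-yl; in this assay compound 2 gives 79.4 nM. The step of a 1.6-fold higher number from compound 1 to compound 2 (0.20 log units; within the scatter) is the only measured one and sits within the scatter, so a change on the aromatic ring of that kind leaves the number essentially unmoved.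

Compound 3 `CC(C)(C)OC(=O)N1CCC(Oc2ncnc3c2CCN3c2ccc(S(C)(=O)=O)cc2F)CC1` is the next compound to be measured. It differs from compound 1 by methyl in place of hydrogen on a saturated chain carbon bound to an oxygen next to a carbonyl group and two saturated chain carbons. For the measured compounds named here, no measured step touches the carbamate end of the molecule, so the expectation rests only on the general smallness of the change and on the flat behaviour seen from compound 1 to compound 2. For compound 3 the expected step is a 1.0-fold lower number from compound 1 to compound 3 (0.00 log units; within the scatter), a movement not beyond the scatter. The estimate for compound 3 in this assay is 50 nM, with a range from 20 nM to 125 nM.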

Compound 3, half-maximal effective concentration: 20 nM
Beside the measured number, compound 3's estimate is 2.5-fold (0.40 log units) above it; measured number inside the range.
By their numbers in this assay, from the lowest: compound 3; then compounds 1 and 2 (each within the scatter of the next).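

In this assay, among the compounds shown here, the change from isopropoxycarbonyl to tert-butoxycarbonyl gives a 2.5-fold lower number from compound 1 to compound 3 (0.40 log units; beyond the scatter) and is the first measured step at the carbamate end of the molecule, which shows that the number responds to a single added methyl on this saturated chain carbon. For the compounds shown here, the only earlier step, a 1.6-fold higher number from compound 1 to compound 2 (0.20 log units; within the scatter) on the aromatic ring, stays within the scatter, so of the two places changed so far, only the carbamate end has moved the number beyond it, and that reading rests on one pair of compounds. Nothing measured on these compounds accounts for the step at the carbamate end.

The compounds shown leave open whether the lower number persists or grows with other groups at this end, such as a longer chain like n-butoxycarbonyl, a cyclobutoxycarbonyl ring, or an amine in place of the carbamate oxygen. They also leave open whether tert-butoxycarbonyl has the same effect when 1,3-thiazol-2-yl replaces methylsulfonyl on the aromatic ring.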